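Swapping the ring-nitrogen carbamate for an amide-bearing chain

The source may hold more compounds than are shown below. What is called first, only, known or untested is meant among the compounds shown, and "the series" means these compounds.

Of the compounds shown here, three sharing one core have been measured in a functional assay on CHO-K1 cells for agonist activity at Glucose-dependent insulinotropic receptor (Homo sapiens), read by a luciferase reporter, with a stated time of 5 h; a higher number here means that more compound is needed for the effect, a lower number that less compound is needed. Compound 1 `CC(C)OC(=O)N1CCC(Oc2cccc3c2CCN3c2ccc(S(C)(=O)=O)cc2F)CC1` gives 1000 nM. Compound 2 `COC(=O)N1CCC(Oc2ncnc3c2CCN3c2ccc(S(C)(=O)=O)cc2F)CC1` gives 316 nM, and compound 3 `CCOC(=O)N1CCC(Oc2ncnc3c2CCN3c2ccc(S(C)(=O)=O)cc2F)CC1` gives 251 nM. Compound 3 shows the lowest number of the three, but its gap to compound 2 is within the scatter, so the two cannot be ranked against each other; only compound 1 sits clearly apart, with a higher number than compound 3. For the measured compounds named here, the one change measured so far, a 1.3-fold lower number from compound 2 to compound 3 (0.10 log units; within the scatter), concerns methyl in place of hydrogen on a saturated chain carbon bound to an oxygen next to a carbonyl group and stays within the scatter.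

Compound 4 `CN(C)C(=O)CN1CCC(Oc2ncnc3c2CCN3c2ccc(S(C)(=O)=O)cc2F)CC1` differs from compound 3 by (dimethylcarbamoyl)methyl in place of ethoxycarbonyl on an amine nitrogen in a ring. Going by the values given here, no measured step touches this kind of swap: the ethoxycarbonyl group is removed altogether rather than lengthened, and an amide-bearing chain takes its place on the ring nitrogen. The measured step therefore gives little guidance, and a moderate loss is expected, a 2.4-fold higher number from compound 3 to compound 4 (0.38 log units; beyond the scatter), with wide uncertainty. Compound 4 is estimated at 600 nM, within a range of 150 nM to 2500 nM.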

Compound 4, half-maximal effective concentration: > 10000 nM
Compound 4 ended at the assay's limit; the forecaster's own chance of this, stated with the estimate: 5%; at least 16-fold (1.22 log units) between middle value and limit.
By their numbers in this assay, from the lowest: compounds 3 and 2 (each within the scatter of the next); then compound 1. At a limit, above all of these: compound 4.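

Compound 4 ended at a limit of this assay, which is a bound and not a measured number: the limit of > 10000 nM in this assay, at which 1 of the 4 values shown sits.

Even so, the swap counts as large, as an at least 39-fold higher number from compound 3 to compound 4 (1.60 log units; beyond the scatter) and an at least 31-fold higher number from compound 2 to compound 4 (1.50 log units; beyond the scatter) both show, whereas the earlier change at the ring nitrogen's carbamate chain stayed within the scatter. This position on the amine nitrogen in a ring is therefore far from indifferent to what sits on it, and the sensitivity appears even though the computed counts barely move: (dimethylcarbamoyl)methyl has 6 heavy atoms against 5 for ethoxycarbonyl, and both groups have no ring, no net charge and no hydrogen-bond donors.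

The swap changes several features at once, so these compounds cannot show whether the loss comes from the carbamate's removal, from the extra carbon linking the carbonyl to the ring nitrogen, or from the dimethylamide itself. Going by these compounds, a plain acetyl group, a simple alkyl chain such as ethyl, or a longer carbamate such as butoxycarbonyl on the same nitrogen would each separate these possibilities, and how far compound 4 lies past the limit also stays open.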